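The source may hold more compounds than are shown below. What is called first, only, known or untested is meant among the compounds shown, and "the series" means these compounds.

Compound 2 has the structure `CC(C)(CO)/N=c1\c(O)c(O)\c1=N/Cc1ccc(C#N)cc1`. In a functional assay for inhibition, with Rattus norvegicus as the target (on this read-out lower numbers stand for stronger inhibition and higher numbers for weaker inhibition), compound 2 gives 21300 nM, the highest number of the three measured here. Its nearest neighbour is compound 1, with structure `CC(/N=c1\c(O)c(O)\c1=N/[C@H](C)C(C)(C)C)c1ccc(C#N)cc1`, which in this assay gives 6500 nM. Furthest from it is compound 3, with structure `CCC(C)(C)/N=c1\c(O)c(O)\c1=N/Cc1ccc(C)cc1C`, which in this assay gives 530 nM. Compound 4, with structure `CC(C)(C)/N=c1\c(O)c(O)\c1=N/Cc1ccc(C#N)cc1`, has not yet been measured. It differs from compound 2 in one place: hydrogen in place of hydroxy on a saturated chain carbon, two bonds along the chain from a double-bonded nitrogen. Among the compounds with values here, no measured pair shows this same change, so no step for it is on record. Compound 4 is nonetheless expected to run a little stronger than compound 2, with a step from a 3.3-fold lower number from compound 2 to compound 4 (0.52 log units; beyond the scatter) that is estimated to exceed the scatter only modestly. Compound 4 is estimated at 6500 nM, within a range from 2000 nM to 20000 nM.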

Compound 4, half-maximal inhibitory concentration: 270 nM
Beside the measured number, compound 4's estimate is 24-fold (1.38 log units) above it, and the stated range ends above it.
By their numbers in this assay, from the lowest: compounds 4 and 3 (each within the scatter of the next); then compound 1; then compound 2.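

In this assay, within the data shown here, the change from hydroxymethyl to methyl, which turns 1-(hydroxymethyl)-1-methylethyl into tert-butyl, gives a 79-fold lower number from compound 2 to compound 4 (1.90 log units; beyond the scatter) and is the first single-place step on record. It shows that at this saturated chain carbon, two bonds along the chain from a double-bonded nitrogen, the hydroxy alone separates much weaker from much stronger inhibition. Nothing measured here accounts for the size of this step. From the compounds shown here alone, an amine or a methoxy group at this carbon remains open, as does whether the step holds in compounds without the nitrile.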